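This account rests on a few compounds, and the source may have more. Where it says the series, first, only, none or still open, it means among the compounds named here.

Compound 1 `COc1ccccc1NC(=O)COc1cc(C)nc2ccc(C(F)(F)F)cc12` was examined in an ADME assay on HepG2 cells (Homo sapiens) for cytotoxicity, read by trypan blue exclusion, with a stated time of 48 h, in the presence of a further agent that is not named here; on this read-out higher numbers stand for lower toxicity in this test and lower numbers for higher toxicity in this test. In this assay compound 1 gives > 128000 nM, which is a limit of the assay and not a number. Two further compounds built on the shared core were measured in the same way. Compound 2 `COc1ccc(NC(=O)COc2cc(C)nc3ccc(OC)cc23)cc1` gives > 142000 nM in this assay, a limit of the assay. Compound 3 `COc1ccc2nc(C)cc(OCC(=O)Nc3ccc(-c4ccccc4)cc3)c2c1` gives > 126000 nM in this assay, again a limit. Compound 1 therefore stands among three values, every one of them a limit and none a number. Among the compounds with values here, the only step between measured compounds that differ in one place is a step that the two limits leave unreadable from compound 2 to compound 3, and its size cannot be read.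

Compound 4 `COc1ccccc1NC(=O)COc1cc(C)nc2ccc(Br)cc12` has not been measured. It differs from compound 1 by bromo in place of trifluoromethyl on an aromatic carbon. Within the data shown here, no measured step touches this change. What the three measured compounds show is that each sits at a limit (the limit of > 126000 nM in this assay, at which 1 of the 3 values shown sits, (the limit of > 128000 nM in this assay, at which 1 of the 3 values shown sits), (the limit of > 142000 nM in this assay, at which 1 of the 3 values shown sits)). On that ground no step beyond the scatter is expected in this assay from compound 1 to compound 4, and compound 4 is expected to sit at a limit as well. The estimated step is a step that the limit leaves unreadable from compound 1 to compound 4. For compound 4 in this assay the estimate is 150000 nM, with a range from 60000 nM to 400000 nM.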

Compound 4, half-maximal cytotoxic concentration: > 125000 nM
Compound 4: only a limit was reported; the forecaster's own chance of this, stated with the estimate: 85%; the middle value does not contradict the limit.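

In this assay compound 4 gives > 125000 nM, which is a limit of the assay and not a number. Within the data shown here, compound 1 also stands at a limit, so no step from compound 1 to compound 4 can be read. The compounds shown leave open how bromo and trifluoromethyl compare in this assay, and at what concentration any of the four compounds would reach half-maximal cytotoxicity.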